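The source may report more compounds than this note shows. Statements on the series, on what has been measured and on what is new or still open speak of the compounds shown alone.

Compound 1 `COc1ccc(C)cc1NC(=S)N/N=C/c1ccc2ccccc2n1` — > 100000 nM
Compound 2 `Cc1ccccc1NC(=S)N/N=C/c1ccc2ccccc2n1` — > 100000 nM

In a functional assay on HeLa cells (Homo sapiens) for antiproliferative activity, read by sulforhodamine B assay, with a stated time of 72 h (a higher number here means a weaker inhibitor, a lower number a stronger inhibitor), compound 1 gives > 100000 nM, which is a limit of the assay and not a number. In this assay compound 2 gives > 100000 nM, again a limit and not a number. Among the measured compounds shown here, compound 2 thus stands at the limit of > 100000 nM in this assay, at which 2 of the 2 values shown sit, and no measured compound gives a number at all. Compound 3 `COc1ccc(NC(=S)N/N=C/c2ccc3ccccc3n2)cc1` has not yet been measured in this assay. It differs from compound 2 by 4-methoxyphenyl in place of 2-methylphenyl on an amide-type nitrogen. For the measured compounds named here, no step between two measured compounds is available, so the size of this change cannot be read from the data. With both measured compounds sitting at the same limit, the expected step is a number no higher from compound 2 to compound 3 (the limit leaves the size open), that is, none beyond the scatter. Compound 3 is expected to come out at 100000 nM, with a range of 30000 nM to 300000 nM, most probably reported again only as a limit.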

Compound 3, half-maximal inhibitory concentration: 72600 nM
Beside the measured number, compound 3's estimate is 1.4-fold (0.14 log units) above it, within the range that was stated.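

In this assay, among the compounds shown here, compound 3 gives 72600 nM, the first actual number, so this place on the amide-type nitrogen can carry an aryl group that gives a readable value. Replacing 2-methylphenyl with 4-methoxyphenyl gives an at least 1.3-fold lower number from compound 2 to compound 3 (0.13 log units; that floor lies within the scatter), and that floor alone does not establish a real difference between the two compounds. Compound 2 remains a limit and not a number, so the true size of the step stays unknown: the limit of > 100000 nM in this assay, at which 2 of the 3 values shown sit.

The compounds shown do not separate the effect of the methoxy group from that of removing the 2-methyl group or of the substituent's ring position. They also leave open how an amine, a carboxylic acid or a longer alkyl chain at this place would read out.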